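The source may hold more compounds than are shown below. What is called first, only, known or untested is meant among the compounds shown, and "the series" means these compounds.

Measured compounds:
compound 1 `CC(C)=CCc1cc(C(=O)Nc2cc3ccc(OCCCN4CCCC4)c(C)c3oc2=O)ccc1O` — 720 nM
compound 2 `CCNCCCOc1ccc2cc(NC(=O)c3ccc(O)c(CC=C(C)C)c3)c(=O)oc2c1C` — 720 nM
compound 3 `CC(C)=CCc1cc(C(=O)Nc2cc3ccc(OCCCNCC(N)=O)c(C)c3oc2=O)ccc1O` — 2290 nM

All three were tested in a functional assay on SK-BR-3 cells (Homo sapiens) for antiproliferative activity; on this read-out higher numbers stand for weaker inhibition and lower numbers for stronger inhibition. Compound 3 gives the highest number of the three: the step of a 3.2-fold higher number from compound 1 to compound 3 (0.50 log units; beyond the scatter) and the step of a 3.2-fold higher number from compound 2 to compound 3 (0.50 log units; beyond the scatter) both lie beyond the scatter, so compound 3 is the weakest inhibitor in this set. Compound 1 and compound 2 sit together, since the step of no change at the digits printed from compound 1 to compound 2 (within the scatter) stays within the scatter.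

The next compound, compound 4 `CC(C)=CCc1cc(C(=O)Nc2cc3ccc(OCCCN(C)Cc4ccccc4)c(C)c3oc2=O)ccc1O`, is not yet measured. It differs from compound 3 in one place: benzyl(methyl)amino in place of (carbamoylmethyl)amino on a saturated chain carbon, three bonds along the chain from an oxygen on an aromatic ring

Among the compounds with values here, two measured steps bear on this change. The step of a 3.2-fold higher number from compound 1 to compound 3 (0.50 log units; beyond the scatter) and the step of a 3.2-fold higher number from compound 2 to compound 3 (0.50 log units; beyond the scatter) show that bringing the carbamoyl-bearing group onto the amine nitrogen raised the number modestly, while the step of no change at the digits printed from compound 1 to compound 2 (within the scatter) shows that exchanging one amine without a carbamoyl group for another left the number unchanged. Compound 4 removes the carbamoyl-bearing group again, so the number is expected to fall back toward those of compound 1 and compound 2, a step estimated at a 3.1-fold lower number from compound 3 to compound 4 (0.48 log units; beyond the scatter). Compound 4 is therefore expected to give about 750 nM, within a range from 300 nM to 2000 nM.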

Compound 4, half-maximal inhibitory concentration: 10700 nM
The estimate for compound 4 lay 14-fold (1.15 log units) below the measured number; measured number above the stated range.
By their numbers in this assay, from the lowest: compounds 1 and 2 (each within the scatter of the next); then compound 3; then compound 4.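

In this assay, within the data shown here, the earlier compounds left the (carbamoylmethyl)amino group as the only change at this place that raised the number, yet benzyl(methyl)amino, which carries no carbamoyl, raises it further (a 4.7-fold higher number from compound 3 to compound 4 (0.67 log units; beyond the scatter)). Against the two amines without a carbamoyl group the rise is larger (a 15-fold higher number from compound 2 to compound 4 (1.17 log units; beyond the scatter) and a 15-fold higher number from compound 1 to compound 4 (1.17 log units; beyond the scatter)), which makes compound 4 the weakest inhibitor of the four and shows that lacking a carbamoyl group does not by itself keep the number low at this place on the chain. Compound 1 also has a nitrogen with no hydrogen on it, so that feature alone does not go with the high number, and nothing measured here accounts for the rise seen with the benzyl(methyl)amino group.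

The compounds shown do not separate the part played by the benzyl group's aromatic ring from that of the methyl on the nitrogen. A benzylamino or a dimethylamino group on the same chain would pull these two apart, and a morpholin-4-yl group would show how far the ring amines follow compound 1.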